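This account rests on a few compounds, and the source may have more. Where it says the series, first, only, none or still open, it means among the compounds named here.

The series rests on one shared core and is followed in a functional assay (Left cardiac atrium, Cavia porcellus), with a stated time of 30 min; a higher number here means that more compound is needed for the effect, a lower number that less compound is needed. Compound 1 `CC1=CSC(O)(c2ccccc2)c2noc(=O)n21` gives 230 nM in this assay. Compound 2 `CC1=CSC(OC(C)C)(c2ccccc2)c2noc(=O)n21` gives 1190 nM in this assay; the two cores differ by hydrogen in place of isopropyl on an oxygen on a saturated carbon, and the step of a 5.2-fold higher number from compound 1 to compound 2 (0.71 log units; beyond the scatter) is a modest one. Compound 3 `COc1ccc(C2(OC(C)C)SC=C(C)n3c2noc3=O)cc1` gives 430 nM in this assay. It differs from compound 2 by methoxy in place of hydrogen on an aromatic carbon, and that change brought a 2.8-fold lower number from compound 2 to compound 3 (0.44 log units; beyond the scatter), again a modest step. Among the three measured numbers compound 1 stands lowest, yet its difference to compound 3 lies within the scatter, so no order between those two is claimed.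

Compound 4 `COc1ccccc1C1(O)SC=C(C)n2c1noc2=O` has not yet been measured. It differs from compound 1 by methoxy in place of hydrogen on an aromatic carbon. Among the measured compounds shown here, this is the same kind of change as the one from compound 2 to compound 3, but not the same: there the methoxy sits para to a large group, here it sits ortho to a large group, and the earlier step can serve only as a guide. For the measured compounds named here, since the single measured instance of a methoxy entering gave a 2.8-fold lower number from compound 2 to compound 3 (0.44 log units; beyond the scatter), a lowering of the number is expected, and the different place widens the uncertainty. The expected step is a 1.9-fold lower number from compound 1 to compound 4 (0.28 log units; within the scatter). Compound 4 is therefore estimated at 120 nM in this assay, with a range from 40 nM to 400 nM.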

Compound 4, half-maximal effective concentration: 930 nM
Compound 4: the middle estimate sits 7.8-fold (0.89 log units) below what was measured, outside the stated range (above it).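

In this assay, methoxy in place of hydrogen on an aromatic carbon brought a 4.0-fold higher number from compound 1 to compound 4 (0.61 log units; beyond the scatter), with the methoxy ortho to a large group. Set beside the earlier case, this shows that the change does not carry over from one core to another in this series as a fixed step, in either size or direction: the same change on two cores in this assay, a 2.8-fold lower number (0.44 log units; beyond the scatter) from compound 2 to compound 3 and a 4.0-fold higher number (0.61 log units; beyond the scatter) from compound 1 to compound 4, 11-fold (1.05 log units) apart, beyond the scatter of two such steps. It does not show why, since the two pairs differ both in where the methoxy sits on the ring and in the group on the oxygen on a saturated carbon, hydrogen in compound 1 and compound 4 against isopropyl in compound 2 and compound 3, and two pairs cannot separate these two differences.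

The compounds shown leave open how a methoxy placed as in compound 3 would behave on the core of compound 1, and how a methoxy ortho to a large group would behave on the core of compound 2. They also leave open whether a chlorine on the same ring, or an ethyl group or a longer chain in place of the isopropyl on the oxygen, would follow either step.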